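Chloro in Place of Hydroxy: Expected Cytotoxicity of Compound 4

A few compounds are considered here, and "the series" means these few. Any claim that something is new, unique, unknown or untested is made for them only; others in the source may bear on it.

Of the compounds shown here, three built on one shared core have been measured in a functional assay on HL-60 cells (Homo sapiens) for cytotoxicity, read by WST assay, with a stated time of 48 h; on this read-out higher numbers stand for an effect only at larger amounts of compound and lower numbers for an effect already at smaller amounts. Compound 1 `COc1cccc(C[C@H]2C(=O)OC[C@@H]2Cc2ccccc2)c1` gives 66000 nM. Compound 2 `O=C1OC[C@H](Cc2ccccc2)[C@H]1Cc1cccc(C(F)(F)F)c1` gives 34000 nM. Going by the values given here, the only step between measured compounds that differ in one place is a 1.9-fold lower number from compound 1 to compound 2 (0.29 log units; within the scatter), a change of trifluoromethyl in place of methoxy on an aromatic carbon. Compound 3 `O=C1OC[C@H](Cc2ccccc2)[C@H]1Cc1ccc(O)cc1` gives 88000 nM, the highest of the three numbers; its gap to compound 1 is within the scatter, while its gap to compound 2 lies beyond it.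

Compound 4 `O=C1OC[C@H](Cc2ccccc2)[C@H]1Cc1ccc(Cl)cc1` is not yet measured. It differs from compound 3 by chloro in place of hydroxy on an aromatic carbon. Among the compounds with values here, no measured step bears directly on this change: nothing shows hydroxy leaving or chloro entering, and the one measured step concerns a different exchange of groups at a different place, of a size within the scatter. The data therefore give no ground for a large step in this assay in either direction, and any step within the scatter remains the most likely outcome. Compound 4 is expected to give about 55000 nM, with a range from 22000 nM to 130000 nM. The estimated step is a 1.6-fold lower number from compound 3 to compound 4 (0.20 log units; within the scatter).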

Compound 4, half-maximal effective concentration: 36000 nM
Compound 4: middle estimate off by 1.5-fold (0.18 log units), on the high side; measured number inside the range.
By their numbers in this assay, from the lowest: compounds 2, 4, 1 and 3 (each within the scatter of the next, the first and the last beyond it).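

Going by these compounds alone, with the step of a 2.4-fold lower number from compound 3 to compound 4 (0.39 log units; beyond the scatter) in this assay, the exchange of 4-hydroxyphenyl for 4-chlorophenyl gives the first change in one place that lies beyond the scatter, though the step is a modest one. It shows that the number responds to the group on this aromatic carbon, para to a large group, and that here chloro calls for a smaller amount of compound than hydroxy, whereas the earlier step from methoxy to trifluoromethyl at a different place stayed within the scatter. The change also takes away the hydrogen-bond donor and acceptor counted for hydroxy, but nothing shown separates their loss from the arrival of chloro, and no measurement at hand accounts for the step.

The compounds shown leave open whether the number follows chloro specifically or would shift in the same way with fluoro, bromo, methyl or methoxy on this carbon. They also leave open how an amine or a carboxylic acid would read here, and whether chloro would give a similar step on another carbon of the same ring.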